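The source may hold more compounds than are shown below. What is called first, only, known or untested is meant among the compounds shown, and "the series" means these compounds.

Measured compounds:
compound 1, `O=C(O)[C@H]1NC[C@H](O)[C@@H](O)[C@@H]1O`, 43%
compound 2, `O=C(O)[C@H]1NC[C@H](O)[C@@H](O)[C@H]1O`, 2.6%
compound 3, `O=C(O)[C@@H]1NC[C@H](O)[C@@H](O)[C@@H]1O`, 5.4%

In an assay on isolated protein for inhibition of cytosolic endo-beta-N-acetylglucosaminidase (Homo sapiens), tested at 1000 uM (a higher number here means more inhibition at the concentration tested (going by the name of the read-out), a lower number less inhibition), compound 3 gives 5.4%, which is far under compound 1 and close to compound 2. All three compounds share the same atoms and bonds and differ only in the configuration as drawn. The step to compound 4, `O=C(O)[C@@H]1NC[C@@H](O)[C@H](O)[C@@H]1O`, is of the same kind: the two compounds have the same atoms and bonds and differ only in configuration as drawn: 2 of 4 stereo elements differ; a stereocentre at a saturated ring carbon is drawn S in compound 3 and R in compound 4; a stereocentre at a saturated ring carbon is drawn R in compound 3 and S in compound 4.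

Among the measured steps, a number 40.4 percentage points lower from compound 1 to compound 2 (beyond the scatter) and a number 37.6 percentage points lower from compound 1 to compound 3 (beyond the scatter) show that inverting a single centre away from compound 1 removes almost all inhibition, while a number 2.8 percentage points higher from compound 2 to compound 3 (within the scatter) shows that inverting two centres between two weak stereoisomers changes nothing beyond the scatter. Compound 4 is a further stereoisomer, again two centres away from compound 3 and not matching compound 1, so a small step in this assay is expected, most likely staying near the weak end, though a rise cannot be excluded from three numbers alone.

Compound 4 is therefore estimated at 10%, within 0% to 40%, meaning an expected step of a number 4.6 percentage points higher from compound 3 to compound 4 (within the scatter).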

Compound 4, a percentage reported as inhibition, at one concentration (the size of the read-out at that concentration, not a potency): 0.8%
Beside the measured number, compound 4's estimate is 9.2 percentage points above it, and the stated range covers the measured number.
By their numbers in this assay, from the lowest: compounds 4, 2 and 3 (each within the scatter of the next); then compound 1.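

Compound 4 joins the weak stereoisomers in this assay: a number 4.6 percentage points lower from compound 3 to compound 4 (within the scatter), and a number 1.8 percentage points lower from compound 2 to compound 4 (within the scatter). That second step joins two mirror images, so inverting all four centres of compound 2 gives a reading that cannot be told apart from it. Compound 1 alone stands apart, with a number 42.2 percentage points lower from compound 1 to compound 4 (beyond the scatter), and since all four compounds share their atoms and bonds, what separates these numbers is configuration alone: the fact that compounds 1 and 4 differ only in the configuration as drawn

Still open, as far as these compounds go, is whether inverting either of the other two centres of compound 1 would also remove its inhibition. Also open, from the compounds shown here alone, is what a methyl ester or a primary amide in place of the carboxylic acid would do, and how potent compound 1 is, given a reading at a single concentration.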